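A few compounds are considered here, and "the series" means these few. Any claim that something is new, unique, unknown or untested is made for them only; others in the source may bear on it.

Measured compounds:
compound 1 `CC1CCC(=NNc2c(Cl)cccc2Cl)c2ncc(C(=O)O)c(=O)n21` – > 100 umol/kg
compound 2 `Cc1cc(NN=C2CCC(C)n3c2ncc(C(=O)O)c3=O)ccc1Br` – > 100 umol/kg

In a functional assay on the whole organism with Rattus norvegicus as the target (a higher number here means that more compound is needed for the effect, a lower number that less compound is needed), compound 1 gives > 100 umol/kg, which is a limit of the assay and not a number. Compound 2 likewise gives > 100 umol/kg, again a limit rather than a measured value. The step that the two limits leave unreadable from compound 1 to compound 2 is therefore not readable in size or direction, and compound 2 stands only at that limit, as summarised by the limit of > 100 umol/kg in this assay, at which 2 of the 2 values shown sit.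

Compound 3 `CC1CCC(=NNc2cccnc2)c2ncc(C(=O)O)c(=O)n21` is not yet measured. It differs from compound 2 in one place: pyridin-3-yl in place of 4-bromo-3-methylphenyl on an amine nitrogen. Going by the values given here, the only measured step with a change at this position is the unreadable one from compound 1 to compound 2, so there is no basis to expect a step of any particular size or direction in this assay. On that thin ground, compound 3 is estimated at 150 umol/kg, between 30 umol/kg and 600 umol/kg, a step that the limit leaves unreadable from compound 2 to compound 3, most likely reported again as a limit.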

Compound 3, dose for 50% inhibition: > 320 umol/kg
Compound 3 ended at the assay's limit (the forecaster's own chance of this, stated with the estimate: 70%); middle value at least 2.1-fold (0.32 log units) from the limit.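

In this assay compound 3 gives > 320 umol/kg, a limit of the assay and not a number. Compound 1 and compound 2 also stand at limits, so no step among these three compounds can be read. The compounds shown leave open whether changing the group on the amine nitrogen alters the dose needed in this assay, and by how much.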